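The source may report more compounds than this note shows. Statements on the series, on what has been measured and on what is new or still open speak of the compounds shown alone.

Measured in a functional assay on PC-3 cells (Homo sapiens) for antiproliferative activity, read by MTT assay, with a stated time of 24 h; on this read-out lower numbers stand for stronger inhibition and higher numbers for weaker inhibition:
- compound 1 `CCN(CC)CCNC(=O)c1ccc(C(CC)(CC)c2ccc(OCS(=O)(=O)c3ccccc3)c(C)c2)n1CC` gives 7130 nM
- compound 2 `CCn1c(C(=O)NC(C)(C)CO)ccc1C(CC)(CC)c1ccc(OCS(=O)(=O)c2ccccc2)c(C)c1` gives 9850 nM

On these numbers, compound 2 cannot be told apart from compound 1. Compound 3 `CCn1c(C(=O)NCCCO)ccc1C(CC)(CC)c1ccc(OCS(=O)(=O)c2ccccc2)c(C)c1` carries 3-hydroxypropyl in place of 1-(hydroxymethyl)-1-methylethyl on an amide-type nitrogen. Within the data shown here, one measured step bears on this change, since it altered the group on the same nitrogen: a 1.4-fold higher number from compound 1 to compound 2 (0.14 log units; within the scatter). That single step gives no reason to expect a shift beyond the scatter in this assay, and no direction can be expected. The expected step is a 1.2-fold lower number from compound 2 to compound 3 (0.06 log units; within the scatter). Compound 3 is estimated at 8500 nM, with an expected range of 4000 nM to 18000 nM.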

Compound 3, half-maximal inhibitory concentration: 11300 nM
Beside the measured number, compound 3's estimate is 1.3-fold (0.12 log units) below it; low and high end bracket the measured number.
By their numbers in this assay, from the lowest: compounds 1, 2 and 3 (each within the scatter of the next).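

In this assay, 3-hydroxypropyl in place of 1-(hydroxymethyl)-1-methylethyl on the amide-type nitrogen gives no readable shift (a 1.1-fold higher number from compound 2 to compound 3 (0.06 log units; within the scatter)), and hydroxymethyl in place of diethylamino on the chain gives none either (a 1.6-fold higher number from compound 1 to compound 3 (0.20 log units; within the scatter)). All three groups on this nitrogen therefore cannot be told apart on these numbers, whether or not the chain carries diethylamino. Nothing measured here offers an explanation for this. Still open, going by these compounds, is whether a carboxylic acid, a morpholine or a longer chain on this nitrogen would move the number beyond the scatter.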